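Compound 4: cyclohexylsulfanyl for benzyloxy on the shared core

A few compounds are considered here, and "the series" means these few. Any claim that something is new, unique, unknown or untested is made for them only; others in the source may bear on it.

Compound 3 `OC[C@H]1O[C@@H](n2cnc3c(OCc4ccccc4)ncnc32)[C@H](O)[C@@H]1O` gives the lowest number in an assay on isolated protein for binding affinity to Equilibrative nucleoside transporter 1 (Homo sapiens) (a lower number here means a stronger inhibitor, a higher number a weaker inhibitor), at 2090 nM. Compound 1 `CCCCCNc1ncnc2c1ncn2[C@@H]1O[C@H](CO)[C@@H](O)[C@H]1O` gives 13500 nM and compound 2 `OC[C@H]1O[C@@H](n2cnc3c(NCc4ccco4)ncnc32)[C@H](O)[C@@H]1O` gives 36300 nM in this assay. Both steps toward compound 3 change the same aromatic carbon, a 6.5-fold lower number from compound 1 to compound 3 (0.81 log units; beyond the scatter) and a 17-fold lower number from compound 2 to compound 3 (1.24 log units; beyond the scatter), so changes at this position have moved the numbers by modest to large amounts. Compound 4 `OC[C@H]1O[C@@H](n2cnc3c(SC4CCCCC4)ncnc32)[C@H](O)[C@@H]1O` carries the change (cyclohexylsulfanyl in place of benzyloxy on an aromatic carbon). Among the measured compounds shown here, no measured step swaps an oxygen link for a sulfur one or an aromatic ring for a saturated one, so the direction is open; a step of modest size in either direction, or none beyond the scatter, is plausible. The expected step is a 1.4-fold lower number from compound 3 to compound 4 (0.14 log units; within the scatter). For compound 4 in this assay the estimate is 1500 nM, within 300 nM to 8000 nM.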

Compound 4, half-maximal inhibitory concentration: 6310 nM
Estimate against measurement, compound 4: 4.2-fold (0.62 log units) below; low and high end bracket the measured number.
By their numbers in this assay, from the lowest: compound 3; then compound 4; then compound 1; then compound 2.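

In this assay the change to cyclohexylsulfanyl raises the number from benzyloxy (a 3.0-fold higher number from compound 3 to compound 4 (0.48 log units; beyond the scatter)) but lowers it from both amino-linked groups (a 5.8-fold lower number from compound 2 to compound 4 (0.76 log units; beyond the scatter)) and (a 2.1-fold lower number from compound 1 to compound 4 (0.33 log units; beyond the scatter)). At this aromatic carbon, the lowest number still belongs to compound 3, and compound 4 shows that a sulfur link with a saturated ring keeps the number below those of pentylamino and ((furan-2-yl)methyl)amino.

Going by these compounds, this step changes the linking atom and the ring together, so their separate contributions stay open. Benzylsulfanyl or cyclohexyloxy on this carbon would separate them. No supporting data explain these steps.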